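The compounds below may be only part of what the source reports. "The series", "measured", "known", "first", "only" and "open" are said of these compounds alone.

Among the measured compounds shown here, in a functional assay on MCF7 cells (Homo sapiens) for inhibition, read by CCK-8 assay, with a stated time of 48 h (on this read-out lower numbers stand for stronger inhibition and higher numbers for weaker inhibition), compound 1 (`COc1cc(-c2ccnc3cc(-c4ccc(F)cc4)nn23)cc(OC)c1OC`) gives 1280 nM, while compound 2 (`COc1cc(-c2ccnc3cc(-c4ccc(C(C)=O)cc4)nn23)cc(OC)c1OC`) gives 5230 nM, the higher and thus weaker of the two numbers so far. Compound 3 (`CCOC(=O)c1ccc(-c2cc3nccc(-c4cc(OC)c(OC)c(OC)c4)n3n2)cc1`) departs from compound 2 by ethoxy in place of methyl on a carbonyl carbon, which turns acetyl into ethoxycarbonyl. For the measured compounds named here, no measured step covers this exact change. The closest evidence is a 4.1-fold higher number from compound 1 to compound 2 (0.61 log units; beyond the scatter), where acetyl replaced fluoro on an aromatic carbon. Compound 3 keeps a carbonyl at that place, so its number is expected to stay close to that of compound 2 rather than return towards that of compound 1. The expected change is small, a 1.2-fold lower number from compound 2 to compound 3 (0.07 log units; within the scatter), and no shift beyond the scatter is anticipated in this assay. The estimate for compound 3 is 4500 nM, with an expected range of 1800 nM to 11000 nM.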

Compound 3, half-maximal inhibitory concentration: > 10000 nM
Compound 3: a limit, no number; the forecaster's own chance of this, stated with the estimate: 5%; middle value at least 2.2-fold (0.34 log units) away from the limit.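

In this assay compound 3 gives a limit, not a number: the limit of > 10000 nM in this assay, at which 1 of the 3 values shown sits. Against acetyl, the change to ethoxycarbonyl is an at least 1.9-fold higher number from compound 2 to compound 3 (0.28 log units; that floor lies within the scatter), so the size of this change stays unknown and the data do not settle whether ethoxy in place of methyl on this carbonyl carbon matters. Against fluoro the change is clear, an at least 7.8-fold higher number from compound 1 to compound 3 (0.89 log units; beyond the scatter), and so both groups shown with a carbonyl at this place, acetyl and ethoxycarbonyl, go with weaker inhibition than fluoro.

From the compounds shown here alone, it remains open how far compound 3 lies past its limit. Going by these compounds, it is also open whether a carboxylic acid or a primary amide at this place would bring the number back towards that of compound 1, and whether a nitrile or a methoxy group would behave like fluoro or like the carbonyl groups.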